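From (oxiran-2-yl)carbonyl to formylmethyl on one nitrogen

A few compounds are considered here, and "the series" means these few. Any claim that something is new, unique, unknown or untested is made for them only; others in the source may bear on it.

In a functional assay on MDA-MB-435 cells (Homo sapiens) for inhibition, read by sulforhodamine B assay, with a stated time of 5 days (on this read-out lower numbers stand for stronger inhibition and higher numbers for weaker inhibition), compound 1 `C=CS(=O)(=O)Nc1cccc(C)c1Nc1ncc(OCc2c(Cl)c(OC)cc(OC)c2Cl)cn1` gives 18200 nM and compound 2 `COc1cc(OC)c(Cl)c(COc2cnc(Nc3c(C)cccc3NC(=O)C3CO3)nc2)c1Cl` gives 24800 nM. Both are large numbers, which on this read-out means weak inhibition. With only these two measurements, compound 2 stands level with compound 1: the step between them is a 1.4-fold higher number from compound 1 to compound 2 (0.13 log units; within the scatter).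

The next compound, compound 3 `COc1cc(OC)c(Cl)c(COc2cnc(Nc3c(C)cccc3NCC=O)nc2)c1Cl`, keeps the shared core and alters a single group: formylmethyl in place of (oxiran-2-yl)carbonyl on a nitrogen on an aromatic ring. Put simply, formylmethyl sits in place of (oxiran-2-yl)carbonyl on a nitrogen on an aromatic ring.

For the measured compounds named here, only one measured step bears on this change, the exchange of vinylsulfonyl for (oxiran-2-yl)carbonyl on that same nitrogen. That exchange gave a 1.4-fold higher number from compound 1 to compound 2 (0.13 log units; within the scatter), so no step beyond the scatter is expected in this assay, although one step is thin evidence and the new group differs from both earlier ones. The expectation therefore starts from compound 2 at 24800 nM. The expected step is a 1.2-fold lower number from compound 2 to compound 3 (0.09 log units; within the scatter). In this assay the estimate for compound 3 is 20000 nM, with an expected range from 6000 nM to 50000 nM.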

Compound 3, half-maximal inhibitory concentration: 66100 nM
Compound 3: the middle estimate sits 3.3-fold (0.52 log units) below what was measured; the measured number lies above the stated range.
By their numbers in this assay, from the lowest: compounds 1 and 2 (each within the scatter of the next); then compound 3.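

In this assay the nitrogen on the aromatic ring turns out to be a place where a change can move the number beyond the scatter: formylmethyl in place of (oxiran-2-yl)carbonyl gives a modest loss (a 2.7-fold higher number from compound 2 to compound 3 (0.43 log units; beyond the scatter)), and formylmethyl in place of vinylsulfonyl gives a similar one (a 3.6-fold higher number from compound 1 to compound 3 (0.56 log units; beyond the scatter)). For the compounds shown here, the two earlier groups stand level with each other, so formylmethyl is the first of the three to separate from the rest, and it is the weakest of them, though all three compounds give large numbers on this read-out. The data shown offer nothing that would explain this loss.

Formylmethyl differs from (oxiran-2-yl)carbonyl both in losing the three-membered ring and in how its carbonyl is placed, so the compounds shown cannot say which of these differences goes with the higher number. Going by these compounds, an acetyl group on the same nitrogen would keep a carbonyl there without the three-membered ring, while a 2-hydroxyethyl chain would keep the length of formylmethyl without any carbonyl, and how either would read in this assay remains open.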